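Working notes: dimethylamino in place of hydroxy on compound 1

The source may hold more compounds than are shown below. What is called first, only, known or untested is meant among the compounds shown, and "the series" means these compounds.

Measured in a functional assay on SK-BR-3 cells (Homo sapiens) for antiproliferative activity, with a stated time of 48 h; on this read-out lower numbers stand for an effect already at smaller amounts and higher numbers for an effect only at larger amounts of compound:
compound 1 `O=C(CCCCCCC(=O)Nc1ccc(O)cc1)NO`: 11000 nM
compound 2 `O=C(CCCCCCC(=O)Nc1cccc(Cl)c1)NO`: 2000 nM

Compound 1 stands highest of the two at 11000 nM, and the gap down to compound 2 at 2000 nM lies beyond the scatter. Compound 3 `CN(C)c1ccc(NC(=O)CCCCCCC(=O)NO)cc1` is not yet measured. It carries dimethylamino in place of hydroxy on an aromatic carbon, para to a large group: dimethylamino in place of hydroxy on an aromatic carbon. Among the compounds with values here, no measured step covers this change. In this assay, within the data shown here, a modest move to a lower number is expected, resting only on compound 2 at 2000 nM as the one lower value. The estimated step is a 2.4-fold lower number from compound 1 to compound 3 (0.39 log units; beyond the scatter). Compound 3 is expected at 4500 nM, with an estimated range of 1500 nM to 12000 nM.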

Compound 3, half-maximal effective concentration: 4200 nM
Estimate against measurement, compound 3: 1.1-fold (0.03 log units) above; measured number inside the range.
By their numbers in this assay, from the lowest: compound 2; then compound 3; then compound 1.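

In this assay, dimethylamino in place of hydroxy on an aromatic carbon, para to a large group, gives a 2.6-fold lower number from compound 1 to compound 3 (0.42 log units; beyond the scatter). Within the data shown here, this is the only measured step so far, and it shows that the number responds to a change at this position and that hydroxy is not required there for a lower number. Nothing measured here gives a reason for this step.

Going by these compounds, whether the hydrogen-bond donor or the added heavy atoms matter remains open, as this single step changes both. Methoxy or methylamino at the same place would help to separate the two.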